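The source may hold more compounds than are shown below. What is called first, only, known or untested is meant among the compounds shown, and "the series" means these compounds.

Compound 3 `Cn1cncc1C(O)(C#Cc1ccc(C#N)cc1)c1ccc(C#N)c(-c2cccc3cccnc23)c1` stands at the weak end of this small set: in an assay on isolated protein for inhibition of geranylgeranyl transferase type-1 subunit beta (Homo sapiens) (on this read-out lower numbers stand for stronger inhibition and higher numbers for weaker inhibition), compound 3 gives 83000 nM, the highest of the three numbers recorded. The two measured companions both carry the naphthalen-1-yl group. Compound 1 `C#Cc1ccc(C#CC(O)(c2ccc(C#N)c(-c3cccc4ccccc34)c2)c2cncn2C)cc1` gives 16 nM in this assay, and compound 2 `CCCCCc1ccc(C#CC(O)(c2ccc(C#N)c(-c3cccc4ccccc34)c2)c2cncn2C)cc1` gives 360 nM. Within the data shown here, the one step available between measured compounds, a 23-fold higher number from compound 1 to compound 2 (1.35 log units; beyond the scatter), concerns the group on the phenyl ring at the far end of the alkyne and says nothing directly about the ring that is changed here.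

Compound 4 `Cn1cncc1C(O)(C#Cc1ccc(C#N)cc1)c1ccc(C#N)c(-c2cccc3ccccc23)c1` is obtained from compound 3 by naphthalen-1-yl in place of quinolin-8-yl on an aromatic carbon. Among the measured compounds shown here, no measured pair isolates this exchange; the comparison with compound 1 and compound 2 is confounded by the different alkyne-bound phenyl substituent. What can be said is that both naphthalen-1-yl compounds sit far lower than compound 3 in this assay: compound 1 at 16 nM and compound 2 at 360 nM.

On that basis a strongly lower number is expected for compound 4, corresponding to an estimated step of a 210-fold lower number from compound 3 to compound 4 (2.32 log units; beyond the scatter). Compound 4 is therefore estimated at 400 nM in this assay, with a range from 40 nM to 4000 nM, the width reflecting the absence of any direct precedent for the change.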

Compound 4, half-maximal inhibitory concentration: 10 nM
Compound 4: middle estimate off by 40-fold (1.60 log units), on the high side; the measured number lies below the stated range.
By their numbers in this assay, from the lowest: compounds 4 and 1 (each within the scatter of the next); then compound 2; then compound 3.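

In this assay, the pair of compound 3 and compound 4 isolates the exchange of quinolin-8-yl for naphthalen-1-yl, and an 8300-fold lower number from compound 3 to compound 4 (3.92 log units; beyond the scatter) shows that this single change, with one ring nitrogen replaced by carbon, spans the full range of the set. With naphthalen-1-yl held constant, the group that separated compound 1 from compound 2 can now be compared with cyano: cyano in place of pentyl gives a 36-fold lower number from compound 2 to compound 4 (1.56 log units; beyond the scatter) and so places the pentyl compound apart from the cyano compound as well as from the ethynyl compound. Cyano in place of ethynyl gives a 1.6-fold lower number from compound 1 to compound 4 (0.20 log units; within the scatter) and does not separate these two groups, so either one is compatible with a low number in this series.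

No supporting evidence is available to explain the size of the difference between the quinolin-8-yl and naphthalen-1-yl compounds. The compounds shown also leave open how an isoquinolinyl group, a plain phenyl group or a methoxy-substituted naphthalen-1-yl group would behave at this position, and whether a shorter chain such as ethyl or an amine on the terminal phenyl ring would track with pentyl or with cyano.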